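The compounds below may be only part of what the source reports. "The series", "measured", "known", "first", "only" and "open" are said of these compounds alone.

Three analogues built on a shared core have been measured in a functional assay on FM3A cells (Mus musculus) for inhibition, read by cell counting, with a stated time of 2 days; on this read-out higher numbers stand for weaker inhibition and lower numbers for stronger inhibition. Compound 1 `C=C(Br)C(=O)Nc1cccc(-c2cn3nc(-c4ccc(OCC)cc4)sc3n2)c1` gives 1100 nM, compound 2 `C=C(Br)C(=O)Nc1cccc(-c2cn3nc(CCc4ccccc4)sc3n2)c1` gives 2600 nM, and compound 3 `C=C(Br)C(=O)Nc1cccc(-c2cn3nc(-c4ccc(Cl)cc4)sc3n2)c1` gives 2000 nM. Compound 3 stands close to both of its companions: a 1.8-fold higher number from compound 1 to compound 3 (0.26 log units; within the scatter) and a 1.3-fold lower number from compound 2 to compound 3 (0.11 log units; within the scatter). Compound 4 `C=C(Br)C(=O)Nc1cccc(-c2cn3nc(Cc4ccc(OC)cc4)sc3n2)c1` differs from compound 3 by 4-methoxybenzyl in place of 4-chlorophenyl on an aromatic carbon. Two of the measured steps touch on this change, the swap of the phenethyl for the 4-chlorophenyl seen in a 1.3-fold lower number from compound 2 to compound 3 (0.11 log units; within the scatter) and the swap of ethoxy for chloro seen in a 1.8-fold higher number from compound 1 to compound 3 (0.26 log units; within the scatter), and neither moved beyond the scatter. No step beyond the scatter is therefore expected in this assay in either direction. Compound 4 is expected to give 1800 nM, between 800 nM and 4000 nM, which would be a 1.1-fold lower number from compound 3 to compound 4 (0.05 log units; within the scatter).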

Compound 4, half-maximal inhibitory concentration: 850 nM
Compound 4: the middle estimate sits 2.1-fold (0.33 log units) above what was measured, within the range that was stated.
By their numbers in this assay, from the lowest: compounds 4, 1, 3 and 2 (each within the scatter of the next, the first and the last beyond it).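

In this assay this aromatic carbon proved able to shift the number beyond the scatter: 4-methoxybenzyl in place of 4-chlorophenyl gave a clear step (a 2.4-fold lower number from compound 3 to compound 4 (0.37 log units; beyond the scatter)), and 4-methoxyphenyl in place of benzyl on the saturated chain gave another (a 3.1-fold lower number from compound 2 to compound 4 (0.49 log units; beyond the scatter)). Against the 4-ethoxyphenyl of compound 1, the 4-methoxybenzyl stayed within the scatter (a 1.3-fold lower number from compound 1 to compound 4 (0.11 log units; within the scatter)), so those two compounds cannot be ordered. Nothing available explains these steps. The compounds shown leave open whether the benzyl link or the methoxy accounts for the step from compound 3. A plain benzyl or a 4-chlorobenzyl group at this carbon would separate the two.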